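The source may hold more compounds than are shown below. What is called first, only, known or untested is meant among the compounds shown, and "the series" means these compounds.

Among the measured compounds shown here, compound 1 `CC(C)CN1CC(c2nc(-c3cccc(Cl)c3)no2)CC1=O` is the only compound here that returns a number in an in vitro functional assay on HEK293-A cells for negative allosteric modulation of metabotropic glutamate receptor 5 (Homo sapiens), read by FLIPR and calcium flux (on this read-out lower numbers stand for stronger inhibition and higher numbers for weaker inhibition), where compound 1 gives 920 nM. Compound 2 `O=C1CC(c2nc(-c3cccc(Cl)c3)no2)CN1c1ccc(Cl)cc1` reaches only the limit of the assay: in this assay compound 2 gives > 10000 nM, a limit and not a number (the limit of > 10000 nM in this assay, at which 1 of the 2 values shown sits). Compound 3 `Cc1cccc(N2CC(c3nc(-c4cccc(Cl)c4)no3)CC2=O)c1` alters the same position as compound 2, (3-methylphenyl in place of isobutyl on an amide-type nitrogen in a ring), again setting an aromatic ring where the isobutyl stood. For the measured compounds named here, the single measured step that bears on this change is an at least 10-fold higher number from compound 1 to compound 2 (1.03 log units; beyond the scatter), a large weakening beyond the scatter. For compound 3 a weakening of comparable size is therefore expected in this assay, a 6.5-fold higher number from compound 1 to compound 3 (0.81 log units; beyond the scatter), with a real chance that the result is again only a limit. The estimate for compound 3 in this assay is 6000 nM, with a range from 1500 nM to 20000 nM.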

Compound 3, half-maximal inhibitory concentration: 2300 nM
For compound 3 the middle estimate is 2.6-fold (0.42 log units) above the measured one, and the stated range covers the measured number.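

With compound 3, an aromatic ring on the amide-type nitrogen returns a number in this assay, so such a ring in place of isobutyl does not by itself take the result to the limit: the step is a 2.5-fold higher number from compound 1 to compound 3 (0.40 log units; beyond the scatter), a modest weakening. The choice of aromatic ring also counts, with 3-methylphenyl in place of 4-chlorophenyl giving an at least 4.3-fold lower number from compound 2 to compound 3 (0.63 log units; beyond the scatter). The value of compound 2 is a limit and not a number, which leaves the full size of that step unknown: the limit of > 10000 nM in this assay, at which 1 of the 3 values shown sits.

The compounds shown do not separate the identity of the substituent from its place on the ring, and a 3-chlorophenyl or 4-methylphenyl group would bear on that. From the compounds shown here alone, it also remains open whether a longer chain or a cyclohexyl group on this nitrogen would improve on compound 1, at 920 nM.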